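The compounds below may be only part of what the source reports. "The series", "measured", "known", "first", "only" and "open" are said of these compounds alone.

The account begins with compound 2 `COc1ccc(-c2c[nH]c(=S)s2)cc1`, which in an assay on isolated protein for inhibition of Indoleamine 2,3-dioxygenase 1 (Homo sapiens), read by colorimetric assay, with stated times of 10 min and 30 min, tested at 100 uM (on this read-out higher numbers stand for more inhibition at the one concentration tested (going by the name of the read-out) and lower numbers for less inhibition), gives 0%. On the numbers shown, compound 2 stands lowest of the three measured compounds. Its nearest neighbour is compound 1 `S=c1[nH]cc(-c2ccccc2)s1`, which in this assay gives 16%, and the furthest is compound 3 `S=c1[nH]c(-c2cccc(Cl)c2)cs1`, which gives 40%. Within the data shown here, the one measured step that touches compound 2 is a number 16 percentage points lower from compound 1 to compound 2 (beyond the scatter), a change described as methoxy in place of hydrogen on an aromatic carbon.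

The next compound, compound 4 `Cc1ccc(-c2c[nH]c(=S)s2)cc1`, differs from compound 2 in one place: methyl in place of methoxy on an aromatic carbon.

Among the measured compounds shown here, no measured step swaps methoxy for methyl, so the only guidance is the step from compound 1 to compound 2, in which adding a methoxy lowered the read-out by a modest amount beyond the scatter. Removing that methoxy in favour of a methyl on the same aromatic carbon is read as a partial reversal of that step, so for compound 4 a small rise in this assay is expected, most likely lying within the scatter of compound 2 or just beyond it. On this reasoning compound 4 is estimated to give 8%, with a range from 0% to 25%, which corresponds to an expected step of a number 8 percentage points higher from compound 2 to compound 4 (within the scatter).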

Compound 4, a percentage reported as inhibition, at one concentration (the size of the read-out at that concentration, not a potency): 15%
Compound 4: middle estimate off by 7 percentage points, on the low side, within the range that was stated.
By their numbers in this assay, from the lowest: compound 2; then compounds 4 and 1 (each within the scatter of the next); then compound 3.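

Among these compounds, on the aromatic carbon para to a group of 6 heavy atoms, the earlier compounds showed only that methoxy in place of hydrogen gave a lower number, leaving open whether any group there would do the same. In this assay the new result separates the two groups, with a number 15 percentage points higher from compound 2 to compound 4 (beyond the scatter) and a number 1 percentage points lower from compound 1 to compound 4 (within the scatter), so on these three compounds the drop goes with methoxy and is not shared by methyl, which cannot be told apart from hydrogen at this carbon. Nothing shown gives a reason why methoxy and methyl differ here, and the data hold no measurement of any property of either group.

On these data alone, what a fluorine, an amine or a carboxylic acid would do on this same carbon remains open, as does whether a longer chain such as ethoxy would track with methoxy or with methyl. All of these numbers are read at a single concentration, so they leave open how the compounds would compare in potency, and whether the gap between methoxy and methyl would hold on a full concentration series.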